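The source may hold more compounds than are shown below. What is called first, only, known or untested is meant among the compounds shown, and "the series" means these compounds.

Three compounds sharing one core have been measured in an assay on isolated protein for inhibition of Amine oxidase [flavin-containing] B (Homo sapiens); on this read-out higher numbers stand for weaker inhibition and lower numbers for stronger inhibition:

Compound 1 `C#CCNC1CCc2c(SCCc3ccc(C)cc3)cccc21` gives 25800 nM.
Compound 2 `C#CCNC1CCc2c(SCc3ccc(Cl)c(Cl)c3)cccc21` gives 2840 nM.
Compound 3 `C#CCNC1CCc2c(SCc3ccc(OC)cc3)cccc21` gives 1900 nM.

Among these three, compound 1 has the highest number and therefore the weakest inhibition in the set; compound 2 sits nearest to it and compound 3 furthest, and both gaps lie beyond the usual scatter. Compound 4 `C#CCNC1CCc2c(SCCc3ccc(OC)cc3)cccc21` has not yet been measured. It differs from compound 1 in one place: methoxy in place of methyl on an aromatic carbon. Compound 3 also carries a methoxy group, but on a shorter chain between the ring and the core, so it and compound 1 differ in two places. Compound 3 alone shows that a methoxy-bearing compound in this series can reach 1900 nM. For the measured compounds named here, no single-change step of this kind is known here, so the size of the move is uncertain; a small shift toward stronger inhibition, possibly still within the scatter, seems the most likely outcome. For compound 4 the expected value is 15000 nM, within a range from 5000 nM to 45000 nM. That estimate means an expected step of a 1.7-fold lower number from compound 1 to compound 4 (0.24 log units; within the scatter).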

Compound 4, half-maximal inhibitory concentration: 62000 nM
The estimate for compound 4 lay 4.1-fold (0.62 log units) below the measured number, outside the stated range (above it).
By their numbers in this assay, from the lowest: compounds 3 and 2 (each within the scatter of the next); then compound 1; then compound 4.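

In this assay, replacing the 4-methylphenyl group with 4-methoxyphenyl on the longer chain weakens inhibition modestly, a 2.4-fold higher number from compound 1 to compound 4 (0.38 log units; beyond the scatter), which shows that the group on this aromatic carbon matters and that methoxy is not an improvement over methyl here. The result also means a methoxy group does not bring strong inhibition by itself: with methoxy in both, compound 3 on the shorter chain gives 1900 nM while compound 4 on the longer chain gives 62000 nM, so the chain length counts as well. Nothing available here explains why the swap weakens inhibition.

The compounds shown leave open whether the same swap would shift the number in the same direction on the shorter chain, and how a hydroxyl group, an amine or a plain hydrogen on this aromatic carbon would compare.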